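Azole exchange on the amide-nitrogen chain carbon

This account rests on a few compounds, and the source may have more. Where it says the series, first, only, none or still open, it means among the compounds named here.

Measured so far:
compound 1 `Cc1noc(C)c1-c1ccc2c(c1)C(c1ccccc1)N(Cc1ncc(-c3ccccc3)o1)C(=O)N2C` — 30%
compound 2 `Cc1nc(-c2ccccc2)sc1CN1C(=O)N(C)c2ccc(-c3c(C)noc3C)cc2C1c1ccccc1` — 28.3%

In a functional assay on HCT-116 cells (Homo sapiens) for inhibition, read by MTT assay, with a stated time of 48 h, tested at 2 uM (a higher number here means more inhibition at the concentration tested (going by the name of the read-out), a lower number less inhibition), compound 1 gives 30% and compound 2 gives 28.3%. On the numbers shown compound 2 is the lower of the two, but the step of a number 1.7 percentage points lower from compound 1 to compound 2 (within the scatter) is within the scatter, so the two are not distinguished.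

Compound 3 `Cc1noc(C)c1-c1ccc2c(c1)C(c1ccccc1)N(Cc1nnc(-c3ccccc3)s1)C(=O)N2C` is not yet measured. It differs from compound 2 by 5-phenyl-1,3,4-thiadiazol-2-yl in place of 4-methyl-2-phenyl-1,3-thiazol-5-yl on a saturated chain carbon bound to an amide-type nitrogen in a ring.

Among the measured compounds shown here, the only measured step at this place, a number 1.7 percentage points lower from compound 1 to compound 2 (within the scatter), lies within the scatter: exchanging the ring on the saturated chain carbon bound to the amide-type nitrogen did not move the number. With a single such step as guide, the expected step of a number 0.3 percentage points lower from compound 2 to compound 3 (within the scatter) is none beyond the scatter, in no particular direction. Compound 3 is therefore estimated at 28%, with a range from 15% to 42%.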

Compound 3, a percentage reported as inhibition, at one concentration (the size of the read-out at that concentration, not a potency): 26.9%
Estimate against measurement, compound 3: 1.1 percentage points above, within the range that was stated.
By their numbers in this assay, from the lowest: compounds 3, 2 and 1 (each within the scatter of the next).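

In this assay, a third ring at this place leaves the picture unchanged: 5-phenyl-1,3,4-thiadiazol-2-yl in place of 4-methyl-2-phenyl-1,3-thiazol-5-yl gives a number 1.4 percentage points lower from compound 2 to compound 3 (within the scatter), and the exchange for 5-phenyl-1,3-oxazol-2-yl gives a number 3.1 percentage points lower from compound 1 to compound 3 (within the scatter), so compounds 1, 2 and 3 are not distinguished. The exchange from compound 2 to compound 3 raises the count of hetero atoms in the five-membered ring from 2 to 3 and of hydrogen-bond acceptors from 2 to 3, and neither difference separates the two compounds here. No measurement on these compounds offers an explanation for the flat result.

Going by these compounds, all three groups at this place are phenyl-bearing five-membered aromatic rings, so what a piperidine or a carboxylic acid would give on the saturated chain carbon bound to an amide-type nitrogen in a ring remains open. On these data alone, each number also comes from a single concentration, so whether compounds 1, 2 and 3 would differ in the size of their effect at other concentrations remains open too.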